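Pyridyl to methylphenyl swap on the amide nitrogen

The source may report more compounds than this note shows. Statements on the series, on what has been measured and on what is new or still open speak of the compounds shown alone.

Compound 1 `O=C(CN1CCN(c2ccccn2)CC1)Nc1cccnc1` gives 86500 nM in a functional assay on cells for antagonist activity at D(4) dopamine receptor (Homo sapiens), read by TR-FRET and cAMP accumulation, with a stated time of 30 min (on this read-out higher numbers stand for weaker inhibition and lower numbers for stronger inhibition), the highest of the three numbers measured. Compound 3 `Cc1cccc(NC(=O)CN2CCC(c3ccc(Cl)cc3)CC2)c1` gives 70200 nM in this assay, a gap to compound 1 inside the usual scatter; compound 2 `O=C(CN1CCN(c2ccc(Cl)cn2)CC1)Nc1cccnc1` gives 40000 nM, and the step of a 2.2-fold lower number from compound 1 to compound 2 (0.33 log units; beyond the scatter) came from chloro in place of hydrogen on an aromatic carbon. Compound 4 `Cc1cccc(NC(=O)CN2CCN(c3ccccn3)CC2)c1` carries 3-methylphenyl in place of pyridin-3-yl on an amide-type nitrogen. For the measured compounds named here, no measured step covers this exchange; the only other 3-methylphenyl amide, compound 3, sits on a different core, and its number lies close to that of compound 1. A step of size a 1.1-fold lower number from compound 1 to compound 4 (0.03 log units; within the scatter) is therefore expected, none beyond the scatter. Compound 4 is estimated at 80000 nM in this assay, within 35000 nM to 180000 nM.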

Compound 4, half-maximal inhibitory concentration: 82.7 nM
For compound 4 the middle estimate is 970-fold (2.99 log units) above the measured one; the whole stated range lies above it.
By their numbers in this assay, from the lowest: compound 4; then compounds 2, 3 and 1 (each within the scatter of the next, the first and the last beyond it).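

For the compounds shown here, with 3-methylphenyl in place of pyridin-3-yl on the amide-type nitrogen, a 1000-fold lower number from compound 1 to compound 4 (3.02 log units; beyond the scatter) in this assay is far larger than the only earlier step, a 2.2-fold lower number from compound 1 to compound 2 (0.33 log units; beyond the scatter) on the shared core, so this position can move the number strongly. The exchange removes a ring nitrogen and adds a methyl together, and the step cannot separate the two. No data shown here give a cause for the step.

As far as these compounds go, whether plain phenyl or 3-methylpyridyl on this nitrogen keeps the low number remains open. Also open, from the compounds shown here alone, is whether chloro on the pyridine ring of compound 4 lowers it further.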